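Pyridin-2-yl to methyl in compound 3

The source may report more compounds than this note shows. Statements on the series, on what has been measured and on what is new or still open speak of the compounds shown alone.

In a physicochemical assay for lipophilicity, at pH 7.4 (on this read-out higher numbers stand for higher lipophilicity and lower numbers for lower lipophilicity), compound 1 (`Cc1cc(C(=O)NCc2ccncc2)nn1Cc1cc(Cl)ccc1OCc1ccccc1`) reads > 3.7, which is a limit of the assay. Compound 2 (`Cc1cc(NC(=O)C2CCCC2)nn1Cc1cc(Cl)ccc1OCc1ccccc1`) gives 3.5. Compound 3 (`Cc1cc(NC(=O)OCc2ccccn2)nn1Cc1cc(Cl)ccc1OCc1ccccc1`) gives 3.1, the lowest of the three.

Compound 4 (`CCOC(=O)Nc1cc(C)n(Cc2cc(Cl)ccc2OCc2ccccc2)n1`) has methyl in place of pyridin-2-yl on a saturated chain carbon bound to an oxygen next to a carbonyl group. The nearest measured step is a number 0.40 log units lower from compound 2 to compound 3 (beyond the scatter), with (pyridin-2-yl)methoxy in place of cyclopentyl on a carbonyl carbon. The step of a number at least 0.60 log units lower from compound 1 to compound 3 (beyond the scatter) rests on a limit and gives only a floor. A modest rise of similar size is expected on removing the ring, with a number 0.40 log units higher from compound 3 to compound 4 (beyond the scatter) as the estimated step. Compound 4 is expected at 3.5, within an estimated range of 3.1 to 3.9.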

Compound 4, distribution coefficient: > 3.7
Compound 4: only a limit was reported; the forecaster's own chance of this, stated with the estimate: 20%; middle value at least 0.20 log units away from the limit.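

In this assay compound 4 reads > 3.7, which is a limit of the assay. Earlier steps exchanged whole groups, whereas here only pyridin-2-yl gives way to methyl, and the result is a number at least 0.60 log units higher from compound 3 to compound 4 (beyond the scatter), while the comparison with the cyclopentyl amide gives only a number at least 0.20 log units higher from compound 2 to compound 4 (that floor lies within the scatter). The step between compound 1 and compound 4 cannot be read, and the full size of both rises stays unknown: the limit of > 3.7 in this assay, at which 2 of the 4 values shown sit.

Still open, from the compounds shown here alone, is how phenyl, an amine or a longer chain would read at this place. Also open, going by these compounds, is whether the step follows the ring nitrogen or the ring as a whole.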